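A few compounds are considered here, and "the series" means these few. Any claim that something is new, unique, unknown or untested is made for them only; others in the source may bear on it.

Measured so far in an in vitro assay on SH-EP1 cells for displacement of a labelled ligand from Neuronal acetylcholine receptor; alpha4/beta2 (Homo sapiens); a lower number here means a stronger inhibitor, a higher number a weaker inhibitor:
compound 1 `Fc1ccc(C2=CC3CNCC(C2)C3)cn1` — 0.4 nM
compound 2 `CN1CC2C=C(c3ccc(F)nc3)CC(C2)C1` — 18 nM

For the measured compounds named here, compound 2 stands at the higher of the two numbers; its only neighbour is compound 1, and the one step measured, a 45-fold higher number from compound 1 to compound 2 (1.65 log units; beyond the scatter), is the one that separates them.

Compound 3 `COc1ccc(C2=CC3CC(C2)CN(C)C3)cn1` differs from compound 2 in a single place: methoxy in place of fluoro on an aromatic carbon. The measured step between compound 1 and compound 2 concerns the amine nitrogen of the shared core, not the aromatic ring, so it does not bear on this exchange. Going by the values given here, no other pair in the set carries a methoxy, and nothing here shows how this change moves the number in this assay. The expectation is therefore a step no larger than the scatter, in either direction, carrying the weaker end of the series forward: a 1.7-fold higher number from compound 2 to compound 3 (0.22 log units; within the scatter) is the estimated step. Compound 3 is estimated at 30 nM, within 8 nM to 120 nM.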

Compound 3, inhibition constant: 797 nM
For compound 3 the middle estimate is 27-fold (1.42 log units) below the measured one, and the stated range ends below it.
By their numbers in this assay, from the lowest: compound 1; then compound 2; then compound 3.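

In this assay the aromatic carbon next to the ring nitrogen turns out to be a sensitive place: methoxy in place of fluoro gives a 44-fold higher number from compound 2 to compound 3 (1.65 log units; beyond the scatter) on the N-methyl form of the core. For the compounds shown here, the earlier compounds showed a change only on the amine nitrogen, with a 45-fold higher number from compound 1 to compound 2 (1.65 log units; beyond the scatter) as the one step, and the ring position now moves the number by a step of similar size, so two separate places on the series each respond strongly. Going by these compounds alone, no measurement available bears on why this exchange moves the number so far.

Still open, from the compounds shown here alone, is whether the change follows methoxy itself or any departure from fluoro, which chloro, an amino group or plain hydrogen on this carbon would help to separate. The compounds shown also leave open how methoxy behaves on the core of compound 1, with hydrogen on the amine nitrogen.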